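Selenium Sugar Nucleosides: Azide Swapped for Hydroxy

The source may hold more compounds than are shown below. What is called first, only, known or untested is meant among the compounds shown, and "the series" means these compounds.

Of the compounds shown here, three built on a selenium-containing five-membered sugar have been tested in a functional assay on A549 cells (Homo sapiens) for cytotoxicity, read by sulforhodamine B assay; a lower number here means a stronger inhibitor, a higher number a weaker inhibitor. Compound 1 `[N-]=[N+]=N[C@@H]1C(n2cc(Br)c(=O)[nH]c2=O)[Se][C@H](CO)[C@H]1O` reached only the limit of the assay, > 100000 nM, so no number is known for it. Compound 2 `Cc1cn(C2[Se][C@H](CO)[C@@H](O)[C@@H]2O)c(=O)[nH]c1=O` likewise stopped at the limit, > 100000 nM. Going by the values given here, compound 3 `[N-]=[N+]=N[C@@H]1C(n2ccc(N)nc2=O)[Se][C@H](CO)[C@H]1O` gives 80100 nM, the only plain number in the set. Compound 1 and compound 2 both sit at the limit of > 100000 nM in this assay, at which 2 of the 3 values shown sit. Compound 4 `Nc1ccn(C2[Se][C@H](CO)[C@@H](O)[C@@H]2O)c(=O)n1` has not yet been tested. It differs from compound 3 by hydroxy in place of azido on a saturated ring carbon. Among the compounds with values here, no step between two measured compounds is available to guide the size of this change. The expected step of a 1.5-fold higher number from compound 3 to compound 4 (0.18 log units; within the scatter) is therefore small, within the usual scatter, and the result could well end at the assay limit again. Compound 4 is estimated at 120000 nM, with a range from 50000 nM to 300000 nM.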

Compound 4, half-maximal inhibitory concentration: 8830 nM
Compound 4: the middle estimate sits 14-fold (1.13 log units) above what was measured, outside the stated range (below it).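

Hydroxy in place of azido on this saturated ring carbon gives a 9.1-fold lower number from compound 3 to compound 4 (0.96 log units; beyond the scatter) in this assay. The group at this position therefore matters for this read-out, and a single change here moves the number beyond the usual scatter. This is also the first step in the set that can be read, and it shows that a compound of this series can land well clear of the point where so many values stop: the limit of > 100000 nM in this assay, at which 2 of the 4 values shown sit.

A single step cannot say whether the same swap would act alike with the rest of the molecule changed, as in compound 1, whose value is only a limit. Going by these compounds, what an amine or a fluorine on the same saturated ring carbon would give also stays open.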